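Hydroxycarbamoyl chain extension: compound 2 to compound 3

A few compounds are considered here, and "the series" means these few. Any claim that something is new, unique, unknown or untested is made for them only; others in the source may bear on it.

Measured compounds, with limits only:
- compound 1 `C=CC(=O)Nc1cc2c(Nc3ccc(OCc4cccc(F)c4)c(Cl)c3)ncnc2cc1OCc1cn(CCCCC(=O)NO)nn1`: > 50000 nM (a limit)
- compound 2 `C=CC(=O)Nc1cc2c(Nc3ccc(F)c(Cl)c3)ncnc2cc1OCc1cn(CCCC(=O)NO)nn1`: > 50000 nM (a limit)

Both compounds were tested in a functional assay on NCI-H838 cells (Homo sapiens) for antiproliferative activity, read by MTT assay, with a stated time of 72 h (a lower number here means a stronger inhibitor, a higher number a weaker inhibitor), and neither gave a number. The position of the pair is summed up as the limit of > 50000 nM in this assay, at which 2 of the 2 values shown sit. Compound 2 therefore has no numerical standing in this assay, only its limit of > 50000 nM.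

Compound 3 `C=CC(=O)Nc1cc2c(Nc3ccc(F)c(Cl)c3)ncnc2cc1OCc1cn(CCCCC(=O)NO)nn1` is the unmeasured neighbour of compound 2. The change is (hydroxycarbamoyl)methyl in place of hydroxycarbamoyl on a saturated chain carbon, three bonds along the chain from an aromatic nitrogen. Cut one bond further out, the same difference reads 3-(hydroxycarbamoyl)propyl to 4-(hydroxycarbamoyl)butyl.

Within the data shown here, no measured step is available in this assay to size this change. A step no larger than the scatter is expected, with no firm direction, and a second limit is a likely outcome. The expected step of a number no higher from compound 2 to compound 3 (the limit leaves the size open) is a rough estimate that treats the limit of compound 2 as its starting point. For compound 3 the estimated value is 50000 nM, with an expected range of 15000 nM to 100000 nM.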

Compound 3, half-maximal inhibitory concentration: > 50000 nM
Compound 3 ended at the assay's limit; the forecaster's own chance of this, stated with the estimate: 65%; the middle value lies on the limit itself.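

In this assay compound 3 gives > 50000 nM, a limit and not a number. The steps joining compound 3 to compound 2 and to compound 1 cannot be read. The series stands at one position: the limit of > 50000 nM in this assay, at which 3 of the 3 values shown sit.

How far either change, the longer hydroxycarbamoyl chain or fluoro in place of (3-fluorobenzyl)oxy, alters activity remains open, since the compounds shown give no numerical value.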